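Amide nitrogen substituent: trimming the chain to hydrogen

The source may hold more compounds than are shown below. What is called first, only, known or untested is meant among the compounds shown, and "the series" means these compounds.

The two measured compounds share one core and differ only at the amide substituent. Compound 1 `CCCNC(=O)C1=CC(C)(C)Oc2ccc([N+](=O)[O-])cc21` and compound 2 `CC1(C)C=C(C(=O)NCCO)c2cc([N+](=O)[O-])ccc2O1` have been run in a functional assay on the whole organism (muscle tissue) with Rattus norvegicus as the target; a higher number here means a larger maximal response, a lower number a smaller maximal response: compound 1 gives 74.1% and compound 2 gives 71.8%. Among the measured compounds shown here, the two numbers sit within the scatter of each other, the single known step being a number 2.3 percentage points lower from compound 1 to compound 2 (within the scatter); that step changed hydroxy in place of methyl on a saturated chain carbon, and the amide-type nitrogen kept its chain throughout. For the measured compounds named here, compound 2 thus stands on a par with the only other measured compound.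

Compound 3 `CC1(C)C=C(C(N)=O)c2cc([N+](=O)[O-])ccc2O1` is not yet measured. It differs from compound 2 by hydrogen in place of 2-hydroxyethyl on an amide-type nitrogen. Going by the values given here, no measured step removes the chain from the amide-type nitrogen; the only step at hand concerns the chain itself and stayed within the scatter, so it bears on the present change only loosely. No movement beyond the scatter is therefore expected, but the range is set wide because the change is of an untested kind. In this assay compound 3 is expected at 70%, with a range from 55% to 85%. The expected step is a number 1.8 percentage points lower from compound 2 to compound 3 (within the scatter), inside the scatter.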

Compound 3, intrinsic activity: the largest response reached, in percent of the reference agonist's: 79.8%
Estimate against measurement, compound 3: 9.8 percentage points below, within the range that was stated.
By their numbers in this assay, from the lowest: compounds 2, 1 and 3 (each within the scatter of the next).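

In this assay, the amide-type nitrogen shows no need for a chain: hydrogen in place of 2-hydroxyethyl gives a number 8 percentage points higher from compound 2 to compound 3 (within the scatter), and hydrogen in place of propyl gives a number 5.7 percentage points higher from compound 1 to compound 3 (within the scatter). The earlier pair varied only the end of the chain, whereas these two steps remove the whole substituent, and the plain carbamoyl of compound 3 still keeps the maximal response in the same range as the two chain-bearing compounds. No measurement at hand speaks to why the three compounds read alike.

From the compounds shown here alone, it remains open whether any substituent on this nitrogen can move the maximal response beyond the scatter, and a longer chain, a phenyl ring, or a chain ending in an amine or a carboxylic acid would test this more severely than the small groups seen so far. Going by these compounds, it is also open whether the same flat reading would hold on a core carrying a nitrile in place of the nitro group, since all three compounds share one core and one read-out.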